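The compounds below may be only part of what the source reports. "The series", "measured", "known", "first", "only" and "open" are said of these compounds alone.

Compound 1 `Cn1c(=O)c(S(=O)(=O)c2ccc([N+](=O)[O-])cc2F)cc2cnc(Nc3ccc4[nH]ccc4c3)nc21` is the more active of the two measured compounds in a functional assay on K562 cells (Homo sapiens) for inhibition, read by trypan blue exclusion, with a stated time of 72 h (a lower number here means a stronger inhibitor, a higher number a weaker inhibitor), where compound 1 gives 200 nM. Compound 2 `Cn1ccc2cc(Nc3ncc4cc(S(=O)(=O)c5ccc(F)cc5F)c(=O)n(C)c4n3)ccc21`, which carries a different sulfonyl substituent and a methylated indole, is weaker, and in this assay compound 2 gives 750 nM, a gap that lies beyond the usual scatter. The next compound, compound 3 `Cn1c(=O)c(S(=O)(=O)Nc2ccc(F)cc2)cc2cnc(Nc3ccc4[nH]ccc4c3)nc21`, keeps the shared core of compound 1 and changes only the group on the sulfonyl sulfur: (4-fluorophenyl)amino in place of 2-fluoro-4-nitrophenyl on a sulfonyl sulfur. Among the measured compounds shown here, no measured pair shows exactly this kind of change, so the size of the step is uncertain. Given that compound 2, with a different sulfonyl substituent, gives 750 nM, compound 3 is expected to lose some activity in this assay, with an estimated step of a 3.0-fold higher number from compound 1 to compound 3 (0.48 log units; beyond the scatter), toward a weaker inhibitor. Compound 3 is therefore estimated to give 600 nM in this assay, within a range from 150 nM to 2500 nM.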

Compound 3, half-maximal inhibitory concentration: 5000 nM
Beside the measured number, compound 3's estimate is 8.3-fold (0.92 log units) below it; the whole stated range lies below it.
By their numbers in this assay, from the lowest: compound 1; then compound 2; then compound 3.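

In this assay the group on the sulfonyl sulfur proves to matter greatly: with the shared core unchanged, (4-fluorophenyl)amino in place of 2-fluoro-4-nitrophenyl gives a 25-fold higher number from compound 1 to compound 3 (1.40 log units; beyond the scatter), a large move toward a weaker inhibitor. Among the compounds shown here, this pair differs in one place only, so the loss belongs to this single exchange, and the earlier compounds could not show that. The exchange also adds a hydrogen-bond donor, but no measurement at hand accounts for the loss.

The compounds shown leave open whether the amino link or the change of ring substituents drives this step, as the two groups differ in both. A 2-fluoro-4-nitrophenylamino group or a 4-fluorophenyl group on the sulfonyl sulfur would separate these two changes.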